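The source may report more compounds than this note shows. Statements on the series, on what has been measured and on what is new or still open speak of the compounds shown alone.

In a functional assay on HeLa cells (Homo sapiens) for cytotoxicity (on this read-out lower numbers stand for stronger inhibition and higher numbers for weaker inhibition), compound 1 (`CCCOC1=CC(=O)c2ccccc2C1=O`) gives 51600 nM as the highest of the three measured numbers, beyond the scatter from the others. Compound 2 (`O=C1C=CC(=O)c2cc(OCc3ccccc3)ccc21`) gives 16800 nM and compound 3 (`CCOc1ccc2c(c1)C(=O)C=CC2=O`) gives 25100 nM on the same read-out. Compound 4 (`O=C1C=C(Oc2ccco2)C(=O)c2ccccc21`) differs from compound 1 as follows: furan-2-yl in place of propyl on an oxygen on an unsaturated carbon with furan-2-yl in place of propyl on an oxygen on an unsaturated carbon. Going by the values given here, one measured step bears on this, and only loosely, as it lies at a different place (a 1.5-fold higher number from compound 2 to compound 3 (0.17 log units; within the scatter)). Among the compounds with values here, it is within the scatter, and no furan-2-yl compound has been measured. A modest expected move towards a lower number in this assay is therefore held with wide uncertainty (a 1.8-fold lower number from compound 1 to compound 4 (0.27 log units; within the scatter)). For compound 4 the estimate is 28000 nM (expected range 9000 nM to 80000 nM).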

Compound 4, half-maximal inhibitory concentration: 37000 nM
Beside the measured number, compound 4's estimate is 1.3-fold (0.12 log units) below it; the range from low to high includes it.
By their numbers in this assay, from the lowest: compounds 2, 3, 4 and 1 (each within the scatter of the next, the first and the last beyond it).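

In this assay, furan-2-yl in place of propyl on an oxygen on an unsaturated carbon gives a 1.4-fold lower number from compound 1 to compound 4 (0.14 log units; within the scatter) and so shows that this position accepts a five-membered aromatic ring in place of an open chain with no change beyond the scatter. Going by these compounds alone, the one earlier step lay at a different place and did not test this position. Nothing available gives a reason for this result.

From the compounds shown here alone, whether a longer chain, an amine or a carboxylic acid at this position would move the number beyond the scatter remains open.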